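Methyl Added to the Core of Compound 3

The source may hold more compounds than are shown below. What is called first, only, known or untested is meant among the compounds shown, and "the series" means these compounds.

Compound 1, `COc1ccccc1-c1cc(O)c2cc(C)cnc2n1`, gives 32400 nM.
Compound 2, `Cc1cnc2nc(-c3ccc(F)cc3)cc(O)c2c1`, gives 33900 nM.
Compound 3, `COc1cccc(-c2cc(O)c3cccnc3n2)c1`, gives 91.2 nM.

Of the compounds shown here, three have been measured in a functional assay on NCI-H460 cells (Homo sapiens); a higher number here means a weaker inhibitor of growth, a lower number a stronger inhibitor of growth. Compound 3 stands lowest of the three numbers with 91.2 nM. The nearest of the other two, compound 1, gives 32400 nM, and compound 2 gives 33900 nM; both gaps to compound 3 are far beyond the scatter. No two of these measured compounds differ in only one place, so none of them offers a direct guide to a single change.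

Compound 4, `COc1cccc(-c2cc(O)c3c(C)ccnc3n2)c1`, differs from compound 3 in one place: methyl in place of hydrogen on an aromatic carbon. Going by the values given here, nothing among the measured compounds shows what a single methyl at this position does on its own. A small step is therefore expected, a 1.3-fold higher number from compound 3 to compound 4 (0.12 log units; within the scatter), in no particular direction and likely within the scatter. Compound 4 is expected to give about 120 nM, with a range from 30 nM to 500 nM.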

Compound 4, concentration for 50% growth inhibition: 47.9 nM
Beside the measured number, compound 4's estimate is 2.5-fold (0.40 log units) above it; the measured number falls inside the stated range.
By their numbers in this assay, from the lowest: compounds 4 and 3 (each within the scatter of the next); then compounds 1 and 2 (each within the scatter of the next).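

In this assay, methyl in place of hydrogen on this aromatic carbon, opposite the ring nitrogen, gives a 1.9-fold lower number from compound 3 to compound 4 (0.28 log units; within the scatter), so the two compounds cannot be told apart. Going by these compounds alone, this is the first single change that can be read directly here, and it shows that this position can carry a methyl with the number staying within the scatter of compound 3. Nothing at hand explains the size of this step.

What the compounds shown leave open is whether this position would accept other groups in the same way, such as a longer chain like ethyl, an amine or a carboxylic acid. Also open, on these data alone, is what methyl does at the other carbons of this ring.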